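Methoxy for cyano on a shared amide core: solubility

A few compounds are considered here, and "the series" means these few. Any claim that something is new, unique, unknown or untested is made for them only; others in the source may bear on it.

Compound 1, `O=C(Nc1nc(-c2cccc(C(F)(F)F)c2F)cs1)c1cnc(N2CCC(C(=O)O)CC2)c(C(F)(F)F)c1`, in a physicochemical assay for solubility; on this read-out higher numbers stand for higher solubility and lower numbers for lower solubility: < 10 ug/mL, which is a limit of the assay.
Compound 2, `N#Cc1cc(C(=O)Nc2nc(-c3cccc(C(F)(F)F)c3F)cs2)cnc1N1CCC(C(=O)O)CC1`, in this assay: < 10 ug/mL, which is a limit of the assay.

The pair differs in one group, and the step that the two limits leave unreadable from compound 1 to compound 2 cannot be sized. Compound 2 therefore stands only at a limit in this assay, and the other value shown is a limit as well, as the limit of < 10 ug/mL in this assay, at which 2 of the 2 values shown sit, records.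

Compound 3, `COc1cc(C(=O)Nc2nc(-c3cccc(C(F)(F)F)c3F)cs2)cnc1N1CCC(C(=O)O)CC1`, has not yet been measured. It differs from compound 2 by methoxy in place of cyano on an aromatic carbon.

For the measured compounds named here, only one measured step bears on this change, and it is the unreadable one from compound 1 to compound 2, so no size can be carried over. Both neighbours sit at the limit. On that basis compound 3 is expected to remain near the limit, with the step that the limit leaves unreadable from compound 2 to compound 3 estimated as no change beyond the scatter, and its solubility in this assay is estimated at 8 ug/mL, in a range from 2 ug/mL to 30 ug/mL.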

Compound 3, solubility: < 10 ug/mL
Compound 3 gave a limit, no number (the forecaster's own chance of this, stated with the estimate: 60%); the middle value lies beyond the limit too.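

Compound 3 also gives only a limit of the assay in this assay, namely < 10 ug/mL and no number. For the compounds shown here, no new step among compound 1, compound 2 and compound 3 can be read. The compounds shown leave open whether trifluoromethyl, cyano and methoxy differ at all in this assay, because all three compounds share one reading: the limit of < 10 ug/mL in this assay, at which 3 of the 3 values shown sit.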